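The source may hold more compounds than are shown below. What is called first, only, known or untested is meant among the compounds shown, and "the series" means these compounds.

Compound 1 `Cc1csc2cc([C@H](C)Nc3ncnc(N)c3C#N)c(-c3cccc(CN4CCC(N(C)CC(C)C)CC4)c3)c(=O)n12` and compound 2 `Cc1csc2cc([C@H](C)Nc3ncnc(N)c3C#N)c(-c3cccc(CN4CCC(N(C)C)CC4)c3)c(=O)n12` share one core and differ in a single place: hydrogen in place of isopropyl on a saturated chain carbon bound to an amine nitrogen. In an ADME assay on the whole organism (lung, Rattus norvegicus) for metabolic stability, read by LC-MS (a lower number here means that the compound disappears faster, a higher number that the compound lasts longer), compound 1 gives 9.9 h, and compound 2 gives 23.2 h, so this change produced a 2.3-fold higher number from compound 1 to compound 2 (0.37 log units; beyond the scatter). Compound 3 `Cc1csc2cc([C@H](C)Nc3ncnc(N)c3C#N)c(Cc3cccc(CN(C)CC(C)C)c3)c(=O)n12` is built on another core; how the two cores differ is not broken down here. In this assay compound 3 gives 2.3 h, the lowest of the three numbers. Compound 4 `Cc1csc2cc([C@H](C)Nc3ncnc(N)c3C#N)c(Cc3cccc(CN(C)C)c3)c(=O)n12` has not yet been measured and differs from compound 3 by the same change: hydrogen in place of isopropyl on a saturated chain carbon bound to an amine nitrogen. Resting on the earlier pair, which showed a 2.3-fold higher number from compound 1 to compound 2 (0.37 log units; beyond the scatter), a step of about a 2.3-fold higher number from compound 3 to compound 4 (0.36 log units; beyond the scatter) is expected here as well. Compound 4 is therefore expected to give about 5.3 h, most likely between 2.5 h and 12 h.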

Compound 4, half-life in the lung assay: 2.3 h
The estimate for compound 4 lay 2.3-fold (0.36 log units) above the measured number; the measured number lies below the stated range.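

In the lung assay the new step reads no change at the digits printed from compound 3 to compound 4 (within the scatter), and the change does not clearly differ between the two cores: the same change on two cores in the lung assay, a 2.3-fold higher number (0.37 log units; beyond the scatter) from compound 1 to compound 2 and no change at the digits printed (within the scatter) from compound 3 to compound 4, 2.3-fold (0.37 log units) apart, within the scatter of two such steps. One step lies beyond the scatter and the other within it, so two pairs do not prove that the change carries over unchanged from core to core. In a physicochemical assay for lipophilicity (on this read-out lower numbers stand for lower lipophilicity and higher numbers for higher lipophilicity), compound 3 gives 2.3 and compound 4 gives 0.8. On the core of compound 3, the half-life stays level while the distribution coefficient falls: the measured distribution coefficient of compound 3, 2.3, and of compound 4, 0.8, a number 1.50 log units lower (beyond the scatter). The compounds shown leave open what a different group on that amine nitrogen, such as an ethyl group, a longer chain or a carboxylic acid, would do to either number. They also leave open how the same change behaves on a third core.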